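A few compounds are considered here, and "the series" means these few. Any claim that something is new, unique, unknown or untested is made for them only; others in the source may bear on it.

Compound 1 `Nc1sc(-c2ccc(Cl)cc2)c(-c2ccc(Cl)cc2)c1C(=O)N1CCCCC1`: 14300 nM
Compound 2 `CC1CN(C(=O)c2c(N)sc(-c3ccc(Cl)cc3)c2-c2ccc(Cl)cc2)CCN1`: 7210 nM
Compound 3 `CC(C)CNC(=O)c1c(N)sc(-c2ccc(Cl)cc2)c1-c1ccc(Cl)cc1`: 13200 nM

These three values come from a functional assay on PC-3 cells (Homo sapiens) for inhibition, read by sulforhodamine B assay, with a stated time of 72 h; on this read-out higher numbers stand for weaker inhibition and lower numbers for stronger inhibition. Compound 3 stands very close to compound 1, and all three compounds lie within the usual scatter of one another.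

Compound 4 `Nc1sc(-c2ccc(Cl)cc2)c(-c2ccc(Cl)cc2)c1C(=O)N1CCNCC1` has not yet been measured. Its structure differs from that of compound 3 as follows: piperazin-1-yl in place of isobutylamino on a carbonyl carbon. In words, piperazin-1-yl sits in place of isobutylamino on a carbonyl carbon.

Within the data shown here, three measured steps bear on this change, and each changes the group at that same carbonyl carbon: a 2.0-fold lower number from compound 1 to compound 2 (0.30 log units; within the scatter), a 1.1-fold lower number from compound 1 to compound 3 (0.03 log units; within the scatter) and a 1.8-fold higher number from compound 2 to compound 3 (0.26 log units; within the scatter). None goes beyond the scatter. The closest guide is compound 2, which carries 3-methylpiperazin-1-yl and gives 7210 nM.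

A small shift towards that value is therefore expected, with the expected 1.5-fold lower number from compound 3 to compound 4 (0.17 log units; within the scatter) staying within the scatter in this assay. For compound 4 the estimated value is 9000 nM, with an expected range from 4500 nM to 18000 nM.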

Compound 4, half-maximal inhibitory concentration: 2710 nM
For compound 4 the middle estimate is 3.3-fold (0.52 log units) above the measured one; measured number outside the range, below it.
By their numbers in this assay, from the lowest: compound 4; then compounds 2, 3 and 1 (each within the scatter of the next).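

In this assay, among these compounds, the group on the carbonyl carbon now makes a difference beyond the scatter, which the earlier compounds never showed: piperazin-1-yl gives a 4.9-fold lower number from compound 3 to compound 4 (0.69 log units; beyond the scatter) when it replaces isobutylamino, and a 5.3-fold lower number from compound 1 to compound 4 (0.72 log units; beyond the scatter) when it replaces piperidin-1-yl. Piperidin-1-yl is also a six-membered non-aromatic ring, so having such a ring at this place is not enough for the lower number. A small change on the ring counts as well: hydrogen in place of methyl on a saturated ring carbon gives a 2.7-fold lower number from compound 2 to compound 4 (0.42 log units; beyond the scatter).

Nothing measured here gives a reason for these steps. On these data alone, it also remains open whether morpholin-4-yl or an open-chain group such as 2-aminoethylamino on this carbonyl carbon would match compound 4.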